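The source may hold more compounds than are shown below. What is called first, only, known or untested is meant among the compounds shown, and "the series" means these compounds.

The measured compounds:
- compound 1, `C/C(=C\C(=O)Nc1ccccc1OCCCC(=O)O)c1ccc2c(ccn2C(c2ccccc2)C(C)C)c1`: 25 nM
- compound 2, `C/C(=C\C(=O)Nc1ccccc1OCCCC(=O)O)c1ccc2c(ccn2C(CC(C)C)c2ccccc2)c1`: 6.3 nM
- compound 3, `C/C(=C\C(=O)Nc1ccccc1OCCCC(=O)O)c1ccc2c(ccn2C(c2ccccc2)c2cccnc2)c1`: 47 nM

In an assay on Prostate gland for inhibition of steroid 5-alpha-reductase (Rattus norvegicus) (on this read-out higher numbers stand for weaker inhibition and lower numbers for stronger inhibition), compound 3 gives the highest of the three numbers. Its gap to compound 1 is small, a 1.9-fold higher number from compound 1 to compound 3 (0.27 log units; within the scatter), so the two cannot be ranked against each other; its gap to compound 2 is larger, a 7.5-fold higher number from compound 2 to compound 3 (0.87 log units; beyond the scatter). Among the measured compounds shown here, the one clear step among the measured compounds, a 4.0-fold lower number from compound 1 to compound 2 (0.60 log units; beyond the scatter), concerns two saturated groups on the same chain carbon and does not involve a pyridine at all.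

Compound 4, `C/C(=C\C(=O)Nc1ccccc1OCCCC(=O)O)c1ccc2c(ccn2C(c2ccccc2)c2ccncc2)c1`, differs from compound 3 only by pyridin-4-yl in place of pyridin-3-yl on a saturated chain carbon bound to an aromatic carbon and an aromatic nitrogen. For the measured compounds named here, no measured step shows what moving the nitrogen within the pyridine ring does here: all three measured steps exchange whole groups of different kind, and none of them compares two pyridines. The account therefore rests on the nearest compound alone, compound 3, and expects for compound 4 a step of roughly a 1.1-fold higher number from compound 3 to compound 4 (0.03 log units; within the scatter) in this assay, that is, nothing that would clearly stand beyond the scatter in either direction. Compound 4 is accordingly estimated at 50 nM in this assay, with the expected range running from 20 nM to 125 nM.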

Compound 4, half-maximal inhibitory concentration: 26 nM
Estimate against measurement, compound 4: 1.9-fold (0.28 log units) above; the range from low to high includes it.
By their numbers in this assay, from the lowest: compound 2; then compounds 1, 4 and 3 (each within the scatter of the next).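

In this assay, among the compounds shown here, the first comparison of two pyridines on this chain carbon gives a 1.8-fold lower number from compound 3 to compound 4 (0.26 log units; within the scatter), so pyridin-4-yl and pyridin-3-yl cannot be told apart at this position, and moving the ring nitrogen shows no readable effect here. Pyridin-4-yl also cannot be separated from isopropyl, with a 1.0-fold higher number from compound 1 to compound 4 (0.02 log units; within the scatter), whereas the exchange of isobutyl for pyridin-4-yl gives a 4.1-fold higher number from compound 2 to compound 4 (0.62 log units; beyond the scatter), which matches what the pyridin-3-yl exchange showed and leaves isobutyl as the only group of the four whose compound stands clearly apart from all the others. No measurement at hand accounts for these results.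

The compounds shown leave open whether pyridin-2-yl, or a plain phenyl in place of the pyridine, would stay level with compound 3 and compound 4 on this chain carbon. They also leave open whether the gain seen with isobutyl extends to a longer chain such as isopentyl or n-pentyl, or whether an amine or a carboxylic acid at the end of such a chain would be tolerated at this position.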